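This account rests on a few compounds, and the source may have more. Where it says the series, first, only, none or still open, it means among the compounds named here.

Compound 1 `Cc1cc(O)c(C2=NN(c3ccc(S(N)(=O)=O)cc3)C(c3ccccc3Cl)C2)cc1Cl` carries a 2-chlorophenyl group on a saturated ring carbon of the shared core. In a functional assay on MCF7 cells (Homo sapiens) for antiproliferative activity, with a stated time of 48 h (on this read-out lower numbers stand for higher toxicity in this test and higher numbers for lower toxicity in this test), compound 1 gives 6350 nM. Compound 2 `COc1ccc(C2CC(c3cc(Cl)c(C)cc3O)=NN2c2ccc(S(N)(=O)=O)cc2)cc1OC` has a 3,4-dimethoxyphenyl group in place of that 2-chlorophenyl group. In this assay compound 2 reaches only > 100000 nM, which is a limit of the assay rather than a number. The change from compound 1 to compound 2 therefore shows an at least 15-fold higher number from compound 1 to compound 2 (1.19 log units; beyond the scatter), and the limit is described by the limit of > 100000 nM in this assay, at which 1 of the 2 values shown sits.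

Compound 3 `COc1ccc(C2CC(c3cc(Cl)c(C)cc3O)=NN2c2ccc(S(N)(=O)=O)cc2)c(OC)c1OC` differs from compound 2 by methoxy in place of hydrogen on an aromatic carbon. Going by the values given here, no measured step concerns adding a methoxy group to a phenyl ring that already bears two; the only measured step, the exchange of the whole aryl group from compound 1 to compound 2, shows that the 3,4-dimethoxyphenyl group already pushes the value to the limit. Compound 2 stands at that limit, so no further rise can be read off, and a fall below it is not indicated by anything shown.

The step from compound 2 to compound 3 is expected to be a step that the limit leaves unreadable from compound 2 to compound 3, within the usual scatter. Compound 3 is expected to give 150000 nM, between 50000 nM and 500000 nM.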

Compound 3, concentration lethal to 50% of the cells: 45600 nM
Estimate against measurement, compound 3: 3.3-fold (0.52 log units) above, and the stated range ends above it.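

In this assay, adding a methoxy group to the 3,4-dimethoxyphenyl ring, at the place ortho to a large group and ortho to a methoxy group, gives an at least 2.1-fold lower number from compound 2 to compound 3 (0.34 log units; beyond the scatter). This shows that the aryl group on the saturated ring carbon still responds to one further substitution, and that the change brings the read-out back into the measurable range, but the true size of the step stays unknown since compound 2 has a limit and not a number: the limit of > 100000 nM in this assay, at which 1 of the 3 values shown sits.

Even so, the 2,3,4-trimethoxyphenyl group does not restore the level seen with the 2-chlorophenyl group, as the comparison shows a 7.2-fold higher number from compound 1 to compound 3 (0.86 log units; beyond the scatter).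

The compounds shown leave open whether the place of the added methoxy group matters or only its presence, since only this one place on the ring is tested. They also leave open how an ethoxy group, a hydroxyl group or an amine at this same place would read in this assay, and whether any other aryl group could give a lower number than compound 1 at 6350 nM.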